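The compounds below may be only part of what the source reports. "The series", "measured", "known", "first", "only" and "open" are said of these compounds alone.

Compound 2 `CC(=O)Nc1cccc(-c2ccc(C(O)(c3c[nH]cn3)C3CC3)cc2)c1` gives 81 nM in an assay on microsomes from Testis (strain Sprague-Dawley) for inhibition of steroid 17-alpha-hydroxylase/17,20 lyase (Rattus norvegicus) (on this read-out higher numbers stand for weaker inhibition and lower numbers for stronger inhibition), the higher of the two numbers obtained so far. Compound 1 `CC(=O)Nc1cccc(-c2ccc(C(O)(c3c[nH]cn3)C(C)C)cc2)c1` gives 17 nM in this assay, and the step of a 4.8-fold higher number from compound 1 to compound 2 (0.68 log units; beyond the scatter) is the only measured one; it bears directly on the present change, since it already shrinks the group at this carbon. Compound 3 `CC(=O)Nc1cccc(-c2ccc(C(O)c3c[nH]cn3)cc2)c1` carries hydrogen in place of cyclopropyl on a saturated chain carbon bound to two aromatic carbons and an oxygen on a saturated carbon. Taking the remaining group away is expected to move the number further in the same direction, by about a 4.3-fold higher number from compound 2 to compound 3 (0.64 log units; beyond the scatter). Compound 3 is therefore estimated at 350 nM in this assay, within a range of 100 nM to 1500 nM.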

Compound 3, half-maximal inhibitory concentration: 320 nM
Beside the measured number, compound 3's estimate is 1.1-fold (0.04 log units) above it; the measured number falls inside the stated range.
By their numbers in this assay, from the lowest: compound 1; then compound 2; then compound 3.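

In this assay, hydrogen in place of cyclopropyl on this saturated chain carbon gives a 4.0-fold higher number from compound 2 to compound 3 (0.60 log units; beyond the scatter), so the loss seen with cyclopropyl continues when the group is removed entirely. Taken from isopropyl, the full removal gives a 19-fold higher number from compound 1 to compound 3 (1.27 log units; beyond the scatter), which places the three compounds in the order isopropyl, cyclopropyl, hydrogen, with a carbon substituent at this position favoured over hydrogen in this set. No measurement available here accounts for this order.

From the compounds shown here alone, whether a tert-butyl group, a longer chain or an amine at this carbon would match or improve on compound 1 remains open.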